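Notes on a carbonyl substituent change toward compound 3

The source may report more compounds than this note shows. Statements on the series, on what has been measured and on what is new or still open speak of the compounds shown alone.

Measured so far in an assay on membranes from CHO cells for displacement of a labelled ligand from adenosine receptor A1 (Homo sapiens), read by scintillation counting, with a stated time of 60 min, tested at 1 uM; on this read-out lower numbers stand for less inhibition and higher numbers for more inhibition at the one concentration tested (going by the name of the read-out):
compound 1, `CCCC(=O)C1=C(C)NC(=O)NC1c1cccs1`: 2%
compound 2, `CCSC(=O)C1=C(C)NC(=O)NC1c1cccs1`: 6%

Both measured compounds share one core and differ only in the group on the carbonyl carbon. Among the measured compounds shown here, the single measured step, a number 4 percentage points higher from compound 1 to compound 2 (within the scatter), puts ethylsulfanyl in place of propyl there. Compound 2 and compound 1 therefore lie within the scatter of each other, and both readings are low in this assay.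

Compound 3, `CCC(CC)OC(=O)C1=C(C)NC(=O)NC1c1cccs1`, is not yet measured. Its change from compound 2 is (pentan-3-yl)oxy in place of ethylsulfanyl on a carbonyl carbon. For the measured compounds named here, this is the same position as the one measured step, so that step is the only one that bears on it. Going by the values given here, that step stayed within the scatter, and nothing measured so far separates any two members beyond it.

On that basis the step from compound 2 to compound 3 is expected to be small, a number 1 percentage points lower from compound 2 to compound 3 (within the scatter), with no direction beyond the scatter. Compound 3 is estimated at 5% in this assay, with a range from -5% to 20%.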

Compound 3, a percentage reported as inhibition, at one concentration (the size of the read-out at that concentration, not a potency): 13%
Beside the measured number, compound 3's estimate is 8 percentage points below it; the measured number falls inside the stated range.
By their numbers in this assay, from the lowest: compounds 1, 2 and 3 (each within the scatter of the next, the first and the last beyond it).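

In this assay, this position on a carbonyl carbon gives its first separation within the series, a number 11 percentage points higher from compound 1 to compound 3 (beyond the scatter), when (pentan-3-yl)oxy replaces propyl. That modest step is the only one so far beyond the scatter, while the change from ethylsulfanyl to (pentan-3-yl)oxy, a number 7 percentage points higher from compound 2 to compound 3 (within the scatter), leaves those two groups unresolved, so the position is not shown to be flat, but no ordering of all three groups is established. No supporting data bear on the reason for the separation.

The change from ethylsulfanyl to (pentan-3-yl)oxy swaps both the linking atom and the chain at once, so ethoxy or ethylsulfanyl's oxygen-free counterparts with a pentan-3-yl chain would be needed to tell which of the two parts matters. Going by these compounds, it also remains open how an amine or a carboxylic acid on this carbonyl carbon, or a longer chain on the oxygen, would read in this assay, and whether any such group would reach well above these low numbers.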